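Compound 4 and a cytotoxicity limit

This account rests on a few compounds, and the source may have more. Where it says the series, first, only, none or still open, it means among the compounds named here.

Measured compounds:
- compound 1 `COc1cc(O)c(C(=O)/C=C/c2cc(OC)c(OC)c(OC)c2)cc1OC`: > 25000 nM
- compound 2 `COc1ccc(O)c(C(=O)/C=C/c2cc(OC)c(OC)c(OC)c2)c1`: > 25000 nM
- compound 3 `COc1cccc(/C=C/C(=O)c2cc(OC)ccc2O)c1`: > 25000 nM

In an ADME assay on THP-1 cells (Homo sapiens) for cytotoxicity, read by MTT assay (on this read-out lower numbers stand for higher toxicity in this test and higher numbers for lower toxicity in this test), compound 3 gives > 25000 nM, which is a limit of the assay and not a number. Going by the values given here, the two other measured compounds read the same way, so the series so far shows only the limit of > 25000 nM in this assay, at which 3 of the 3 values shown sit, and offers no ranking among the three.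

Compound 4 `COc1ccc(O)c(C(=O)/C=C/c2ccc(OC)c(OC)c2)c1` arises from compound 3 by one change, methoxy in place of hydrogen on an aromatic carbon.

Among the compounds with values here, one measured step bears on this, since it is the same kind of change run in reverse, at another place on the core: a step that the two limits leave unreadable from compound 1 to compound 2. That step gives no size to carry over. No change beyond the scatter is therefore expected in this assay, and no direction can be given. Compound 4 is expected to read as a limit too, like compound 3, because the limit of > 25000 nM in this assay, at which 3 of the 3 values shown sit, is all the series has shown.

The expected change is a step that the limit leaves unreadable from compound 3 to compound 4, an estimate and not a measurement. For compound 4 the estimated value is 30000 nM, with an expected range from 15000 nM to 80000 nM.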

Compound 4, half-maximal cytotoxic concentration in the THP-1 assay: > 50000 nM
Compound 4: a limit, no number; the forecaster's own chance of this, stated with the estimate: 85%; middle value at least 1.6-fold (0.22 log units) from the limit.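

In the THP-1 assay compound 4 gives > 50000 nM, which is a limit of the assay and not a number. No step can be read from it, either against compound 3 or against compound 2, whose values are limits too. The compounds shown leave open whether adding or removing a methoxy on the shared core changes the result in the THP-1 assay at all. In a physicochemical assay for lipophilicity (a higher number here means a more lipophilic compound, a lower number a more polar compound), compound 3 gives 3.87 and compound 4 gives 3.52. In the physicochemical assay this is a number 0.35 log units lower from compound 3 to compound 4 (beyond the scatter).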